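A few compounds are considered here, and "the series" means these few. Any claim that something is new, unique, unknown or untested is made for them only; others in the source may bear on it.

Compound 1, `COc1cc(CNC(=S)NCC(COC(=O)C(C)(C)C)Cc2ccc(C(C)(C)C)cc2)cc(Cl)c1O`: in an assay on CHO cells for displacement of a labelled ligand from transient receptor potential cation channel subfamily V member 1 (Rattus norvegicus) (a lower number here means a stronger inhibitor, a higher number a weaker inhibitor), compound 1 gives 21.3 nM.
Compound 2, `COc1cc(CNC(=S)NCC(COC(=O)C(C)(C)C)Cc2ccc(C)c(C)c2)cc(Cl)c1O`: in this assay compound 2 gives 30.9 nM.

Compound 2 has the higher of the two numbers, but the step of a 1.5-fold higher number from compound 1 to compound 2 (0.16 log units; within the scatter) lies within the scatter, so the two compounds cannot be ordered. Compound 3, `COc1cc(CNC(=S)NCC(COC(=O)C(C)(C)C)Cc2ccc(C)c(C)c2)c(I)cc1O`, differs from compound 2 in one place: 4-hydroxy-2-iodo-5-methoxyphenyl in place of 3-chloro-4-hydroxy-5-methoxyphenyl on a saturated chain carbon bound to an amide-type nitrogen. Within the data shown here, the one measured step alters a different part of the molecule, so no measured step bears on this change, and the expectation rests on the structural change alone. The expected step of a 3.2-fold higher number from compound 2 to compound 3 (0.51 log units; beyond the scatter) leans toward a higher number, with wide uncertainty. For compound 3 the estimated value is 100 nM, within a range from 25 nM to 400 nM.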

Compound 3, inhibition constant: 18.9 nM
Estimate against measurement, compound 3: 5.3-fold (0.72 log units) above; the measured number lies below the stated range.
By their numbers in this assay, from the lowest: compounds 3, 1 and 2 (each within the scatter of the next).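

In this assay, the step is a 1.6-fold lower number from compound 2 to compound 3 (0.21 log units; within the scatter), so these two substituted phenyl groups cannot be told apart here, even though the halogen differs and sits elsewhere on the ring. Because both differences come together, this step cannot separate the halogen's identity from its location. Nothing available explains why the two compounds read alike.

Still open, going by these compounds, is whether bromine in place of iodine, or a plain hydrogen there, would read the same. On these data alone, it is also open whether 4-hydroxy-2-iodo-5-methoxyphenyl would match this result alongside the 4-(tert-butyl)phenyl group of compound 1.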